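The source may hold more compounds than are shown below. What is called first, only, known or untested is meant among the compounds shown, and "the series" means these compounds.

Measured in a functional assay on HepG2 cells (Homo sapiens) for inhibition, read by scintillation counting, with a stated time of 2 h; a lower number here means a stronger inhibitor, a higher number a weaker inhibitor:
- compound 1 `CCCC(=O)N1CCC(N2CCN(C(=O)c3c(NC(=O)NCC)sc4ccccc34)CC2)CC1`: "not determined" (no result reported)
- compound 2 `CCCCC(=O)N1CCC(N2CCN(C(=O)c3c(NC(=O)NCC)sc4ccccc34)CC2)CC1`: "not determined" (no result reported)
- compound 3 `CCNC(=O)Nc1sc2ccccc2c1C(=O)N1CCN(C2CCN(C(=O)C3CCCC3)CC2)CC1`: 309 nM

Among the measured compounds shown here, compound 3 holds the only number, so it cannot yet be ranked against anything. Compound 4 `CCNC(=O)Nc1sc2ccccc2c1C(=O)N1CCN(C2CCN(C(=O)C3CCCCC3)CC2)CC1` is the next entry, and the change from compound 3 is cyclohexyl in place of cyclopentyl on a carbonyl carbon, with cyclohexyl in place of cyclopentyl on a carbonyl carbon. For the measured compounds named here, no step between measured compounds is available for calibration, so the expectation rests on compound 3 at 309 nM and on the modest size of the change. In this assay no shift beyond the scatter is expected, and no direction is favoured. The expected step is a 1.1-fold lower number from compound 3 to compound 4 (0.03 log units; within the scatter) and would stay within the scatter. For compound 4 the estimate is 290 nM, with an expected range of 100 nM to 850 nM.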

Compound 4, half-maximal inhibitory concentration: 146 nM
Estimate against measurement, compound 4: 2.0-fold (0.30 log units) above; low and high end bracket the measured number.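

In this assay, among the compounds shown here, cyclohexyl in place of cyclopentyl on a carbonyl carbon gives a 2.1-fold lower number from compound 3 to compound 4 (0.33 log units; beyond the scatter), the first readable step. It shows that the group at this place can move the number beyond the scatter, here in favour of the six-membered ring. Steps involving compound 1 or compound 2 cannot be read.

On these data alone, how a cycloheptyl or phenyl group on the same carbonyl carbon would read remains open. No evidence at hand bears on this step.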